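The source may report more compounds than this note shows. Statements on the series, on what has been measured and on what is new or still open speak of the compounds shown alone.

Of the compounds shown here, three sharing a core have been read in an ADME assay (liver, Mus musculus) for metabolic stability, read by LC-MS, using microsomes, tested at 1 uM; on this read-out higher numbers stand for a longer-lived compound and lower numbers for a shorter-lived compound: compound 1 `CCN(CC)CCCN/C(=N\c1ccnc2cc(Cl)ccc12)c1cccnc1`, compound 2 `C/C(=N/c1ccnc2cc(Cl)ccc12)NC1CCN(Cc2ccccc2)CC1` and compound 3 `CCN(CC)CCCCN/C(=N\c1ccnc2cc(Cl)ccc12)C(C)C`. Compound 1 gives > 1 h, which is a limit of the assay and not a number. Compound 2 gives > 1 h, which is also a limit. Going by the values given here, compound 3 gives 0.7 h, the only actual number among the three. Compound 2 therefore stands at the limit of > 1 h in this assay, at which 2 of the 3 values shown sit, and its exact half-life is not known. No two of these compounds differ in a single place, so no measured step serves as a guide.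

Compound 4 `C/C(=N/c1ccnc2cc(Cl)ccc12)NC1CCN(C)CC1` departs from compound 2 by one change: hydrogen in place of phenyl on a saturated chain carbon bound to an amine nitrogen in a ring. In words, this is hydrogen in place of phenyl on a saturated chain carbon bound to an amine nitrogen in a ring, and cut one bond further out it reads benzyl to methyl. With compound 2 known only as a limit, no step beyond the scatter is expected in this assay, in either direction. The estimated step that the limit leaves unreadable from compound 2 to compound 4 is expected to stay within the usual scatter. For compound 4 the expected half-life is 1.3 h. The estimated range for that value runs from 0.6 h to 3 h.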

Compound 4, half-life: > 1 h
Compound 4: a limit, no number; the forecaster's own chance of this, stated with the estimate: 60%; the middle value is on the limit's open side.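

Compound 2 and compound 4 each sit at a limit and not at a number, so no step can be read between them: the limit of > 1 h in this assay, at which 3 of the 4 values shown sit.

The compounds shown leave open what the actual half-life of compound 2 and compound 4 is, and whether the change from benzyl to methyl alters it at all.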